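Replacing the amide of compound 3 with an aryl ester

A few compounds are considered here, and "the series" means these few. Any claim that something is new, unique, unknown or untested is made for them only; others in the source may bear on it.

Measured so far in an assay on HL-60 cells for agonist activity at vitamin D3 receptor (Homo sapiens), read by microscopy, with a stated time of 96 h; on this read-out higher numbers stand for an effect only at larger amounts of compound and lower numbers for an effect already at smaller amounts:
compound 1 `CC[C@@H](C)[C@H](NC(=O)c1ccc(C(CC)(CC)c2ccc(OCC(=O)C(C)(C)C)c(C)c2)n1CC)C(=O)OC`: 590 nM
compound 2 `CCOC(=O)CC(C)OC(=O)c1ccc(C(CC)(CC)c2ccc(OCC(=O)C(C)(C)C)c(C)c2)n1CC`: only a limit, > 50000 nM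
compound 3 `CC[C@@H](C)[C@H](NC(=O)c1ccc(C(CC)(CC)c2ccc(OCC(O)C(C)(C)C)c(C)c2)n1CC)C(=O)OC`: 26 nM

Compound 3 has the lowest number of the two numbers in this assay ; its nearest neighbour is compound 1, which differs only in carrying (tert-butyl)carbonyl where compound 3 carries 1-hydroxy-2,2-dimethylpropyl, and the step of a 23-fold lower number from compound 1 to compound 3 (1.36 log units; beyond the scatter) is large. The value of compound 2 is a limit of the assay, (the limit of > 50000 nM in this assay, at which 1 of the 3 values shown sits), not a number.

Compound 4 `CCOC(=O)c1ccc(OC(=O)c2ccc(C(CC)(CC)c3ccc(OCC(O)C(C)(C)C)c(C)c3)n2CC)cc1` is compound 3 with one change: 4-(ethoxycarbonyl)phenoxy in place of (1-(methoxycarbonyl)-2-methylbutyl)amino on a carbonyl carbon. Among the measured compounds shown here, the one measured step that touches the same carbonyl carbon is an at least 84-fold higher number from compound 1 to compound 2 (1.92 log units; beyond the scatter), where a group of six carbon and three oxygen atoms took the place of the amino group and the response was lost. The group entering in compound 4 again has no hydrogen-bond donor, so a large rise in number is expected, a 150-fold higher number from compound 3 to compound 4 (2.19 log units; beyond the scatter). Compound 4 is therefore estimated at 4000 nM, with a range from 300 nM to 50000 nM.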

Compound 4, half-maximal effective concentration: > 50000 nM
Compound 4: a limit, no number; the forecaster's own chance of this, stated with the estimate: 30%; middle value at least 12-fold (1.09 log units) from the limit.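

In this assay, the change to 4-(ethoxycarbonyl)phenoxy gives an at least 1900-fold higher number from compound 3 to compound 4 (3.28 log units; beyond the scatter), so a replacement on this carbonyl carbon can also remove the response in a compound carrying 1-hydroxy-2,2-dimethylpropyl, the group linked to the lower number in a 23-fold lower number from compound 1 to compound 3 (1.36 log units; beyond the scatter). The value of compound 4 is a limit and not a number: the limit of > 50000 nM in this assay, at which 2 of the 4 values shown sit. Both replacements of the amino group shown now end at that limit, one with a six-membered aromatic ring and one with no ring, and neither entering group has a hydrogen-bond donor.

From the compounds shown here alone, how far the response falls in either compound remains unknown. Going by these compounds, it also remains open whether an amide nitrogen carrying 4-(ethoxycarbonyl)phenyl would keep the response, which would separate the amide hydrogen from the entering group.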